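Working notes: replacing the terminal amine of compound 2

The source may hold more compounds than are shown below. What is called first, only, known or untested is meant among the compounds shown, and "the series" means these compounds.

Measured in a functional assay (aorta) with Rattus norvegicus as the target (on this read-out lower numbers stand for stronger inhibition and higher numbers for weaker inhibition), so far:
- compound 1 `CCCN(CCC)CCCOc1ccc(S(=O)(=O)c2c(C)cn3ccccc23)cc1` gives 957 nM
- compound 2 `CCCN(CCC)CCCOc1ccc(S(=O)(=O)c2c(CC)cn3ccccc23)cc1` gives 150 nM

Compound 2 stands at 150 nM as the lower of the two numbers, beyond the scatter from compound 1. Compound 3 `CCc1cn2ccccc2c1S(=O)(=O)c1ccc(OCCCN2CCCCC2)cc1` keeps the core of compound 2 and differs in one place, with piperidin-1-yl in place of dipropylamino on a saturated chain carbon, three bonds along the chain from an oxygen on an aromatic ring as the counted change, namely piperidin-1-yl in place of dipropylamino on a saturated chain carbon, three bonds along the chain from an oxygen on an aromatic ring.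

Among the measured compounds shown here, the only measured step is a 6.4-fold lower number from compound 1 to compound 2 (0.80 log units; beyond the scatter) at a different place, methyl in place of hydrogen on a saturated chain carbon bound to an aromatic carbon. For the measured compounds named here, no measured pair covers the amine, so that step gives no direct guide to direction. Going by the values given here, its size shows only that one small change moved this assay beyond the scatter here. A modest shift toward a higher number is expected, on thin evidence, and a result within the scatter remains possible. The expected step is a 1.7-fold higher number from compound 2 to compound 3 (0.22 log units; within the scatter) in this estimate. For compound 3 the estimated value is 250 nM with 70 nM to 900 nM as the expected range.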

Compound 3, half-maximal inhibitory concentration: 357 nM
Compound 3: the middle estimate sits 1.4-fold (0.15 log units) below what was measured; measured number inside the range.
By their numbers in this assay, from the lowest: compound 2; then compound 3; then compound 1.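

In this assay, replacing dipropylamino with piperidin-1-yl gives a 2.4-fold higher number from compound 2 to compound 3 (0.38 log units; beyond the scatter) and so moves the read-out toward weaker inhibition. Among the compounds shown here, the amine end of the chain is therefore a second place, after the one changed between compound 1 and compound 2, where a single change moves the number beyond the scatter. The change replaces an open-chain group with one six-membered non-aromatic ring with 1 hetero atom, and on this single pair the open-chain dipropylamino group gives the stronger inhibition, though no measurement at hand bears on the reason for this direction.

Open, as far as these compounds go, is whether another ring amine such as pyrrolidin-1-yl or morpholin-4-yl, or a smaller open-chain amine such as dimethylamino, would stand nearer compound 2 or compound 3 in this assay, and whether a longer chain between the oxygen and the amine would shift the number. Also open, from the compounds shown here alone, is whether piperidin-1-yl in place of dipropylamino would move the number the same way on the core of compound 1.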